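A few compounds are considered here, and "the series" means these few. Any claim that something is new, unique, unknown or untested is made for them only; others in the source may bear on it.

Compounds measured so far:
compound 1 `CCNC(=O)n1cc(C(=O)c2ccn3c2CSC3c2cccnc2)c2ccc(-c3ccc(F)cc3)cc21` in a functional assay on the whole organism for inhibition, with Rattus norvegicus as the target (on this read-out lower numbers stand for an effect already at smaller amounts and higher numbers for an effect only at larger amounts of compound), gives 0.18 mg/kg
compound 2 `NC(=O)n1cc(C(=O)c2ccn3c2CSC3c2cccnc2)c2ccc(-c3ccc(F)cc3)cc21` in this assay gives 0.01 mg/kg

Of these two numbers, compound 1 holds the higher one. The measured step of an 18-fold lower number from compound 1 to compound 2 (1.26 log units; beyond the scatter) shows what removing the ethyl does. Compound 3 `NNC(=O)n1cc(C(=O)c2ccn3c2CSC3c2cccnc2)c2ccc(-c3ccc(F)cc3)cc21` carries instead (amino in place of ethyl on an amide-type nitrogen), that is ethylcarbamoyl becomes aminocarbamoyl. Among the compounds with values here, the one relevant step, from compound 1 to compound 2, was large and downward; the amino group is also small but is not hydrogen, so a smaller step of the same direction is expected. For compound 3 the estimate is a 6.0-fold lower number from compound 1 to compound 3 (0.78 log units; beyond the scatter), giving 0.03 mg/kg with a range from 0.008 mg/kg to 0.12 mg/kg.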

Compound 3, dose for half-maximal effect: 0.04 mg/kg
For compound 3 the middle estimate is 1.3-fold (0.12 log units) below the measured one; the measured number falls inside the stated range.
By their numbers in this assay, from the lowest: compound 2; then compound 3; then compound 1.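

Replacing ethyl with amino on the amide-type nitrogen gives a 4.5-fold lower number from compound 1 to compound 3 (0.65 log units; beyond the scatter) in this assay, so a group other than hydrogen can stand at this position without the number returning to that of compound 1. The same amino group, set against hydrogen, gives a 4.0-fold higher number from compound 2 to compound 3 (0.60 log units; beyond the scatter) and so leaves compound 2 with the lowest number of the three. No measurement shown here accounts for this order.

Only hydrogen, amino and ethyl are shown on this nitrogen. Where a methyl, a hydroxyl or a longer chain would fall remains open.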